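Methoxymethyl added to the dihydropyrimidinone of compound 2

This account rests on a few compounds, and the source may have more. Where it says the series, first, only, none or still open, it means among the compounds named here.

Measured compounds:
compound 1 `COCC1=C(C(=O)NCCCN2CCC(c3ccccc3C#N)CC2)[C@@H](c2ccc(F)c(F)c2)NC(=O)N1` 285 nM
compound 2 `O=C1NC=C(C(=O)NCCCN2CCC(c3ccccn3)CC2)[C@@H](c2ccc(F)c(F)c2)N1` 1850 nM

In an assay on LM cells with Alpha-1B adrenergic receptor (Homo sapiens) as the target (on this read-out higher numbers stand for weaker inhibition and lower numbers for stronger inhibition), compound 1 gives 285 nM. Compound 2 gives the higher of the two numbers in this assay, 1850 nM, and the gap to compound 1 lies beyond the scatter. Within the data shown here, the two compounds differ in two places, so no single step between them is recorded.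

Compound 3 `COCC1=C(C(=O)NCCCN2CCC(c3ccccn3)CC2)[C@@H](c2ccc(F)c(F)c2)NC(=O)N1` keeps the pyridyl-bearing side chain of compound 2 and carries methoxymethyl in place of hydrogen on a double-bonded ring carbon. Compound 1 carries the same methoxymethyl group on the shared core together with a different aryl on the piperidine, and sits lower than compound 2; how much of that gap belongs to the methoxymethyl alone cannot be separated from these two numbers.

For compound 3 the expected step from compound 2 is a 2.6-fold lower number from compound 2 to compound 3 (0.42 log units; beyond the scatter), leaning toward a lower number in this assay but with wide uncertainty. The estimate for compound 3 in this assay is 700 nM, with a range from 200 nM to 2500 nM.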

Compound 3, inhibition constant: 235 nM
The estimate for compound 3 lay 3.0-fold (0.47 log units) above the measured number, within the range that was stated.
By their numbers in this assay, from the lowest: compounds 3 and 1 (each within the scatter of the next); then compound 2.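

In this assay, methoxymethyl in place of hydrogen on the double-bonded ring carbon gives a 7.9-fold lower number from compound 2 to compound 3 (0.90 log units; beyond the scatter), so the contribution of this position, which compound 1 and compound 2 could not separate, can now be read on its own with the pyridin-2-yl side chain. With methoxymethyl held in place, pyridin-2-yl in place of 2-cyanophenyl on the saturated ring carbon gives a 1.2-fold lower number from compound 1 to compound 3 (0.08 log units; within the scatter), and the two groups cannot be told apart in this assay. Nothing measured in this series speaks to the origin of the methoxymethyl step.

On these data alone, it remains open whether this step needs the ether oxygen, a question that a methyl, ethyl or hydroxymethyl group on the same carbon would address. Also open, as far as these compounds go, is whether the same step holds with 2-cyanophenyl in place of pyridin-2-yl.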